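Trading Methoxy for Cyclopropyl on a Shared Core

A few compounds are considered here, and "the series" means these few. Any claim that something is new, unique, unknown or untested is made for them only; others in the source may bear on it.

Two compounds have been measured in an assay on isolated protein for inhibition of activin receptor type-2A (Homo sapiens), read by 33P incorporation, with a stated time of 20 min, in the presence of a further agent that is not named here; a higher number here means a weaker inhibitor, a lower number a stronger inhibitor:

compound 1 `CNc1nc2c(-c3ccnc(OC)c3)cnn2cc1C`: 1300 nM
compound 2 `CNc1nc2c(-c3ccnc(OC)c3)cnn2cc1OC`: 310 nM

Compound 2 holds the lower of these two numbers; the step of a 4.2-fold lower number from compound 1 to compound 2 (0.62 log units; beyond the scatter) separates it from compound 1. Compound 3 `CNc1nc2c(-c3ccnc(OC)c3)cnn2cc1C1CC1` differs from compound 2 by cyclopropyl in place of methoxy on an aromatic carbon. Going by the values given here, the only measured step that bears on this place is the one from compound 1 to compound 2, where methyl gave way to methoxy. Cyclopropyl, like methyl, carries no hydrogen-bond acceptor, so a return toward the higher number of compound 1 is expected, though softened by the larger group. Compound 3 is therefore estimated at 700 nM, between 250 nM and 2000 nM, which would mean the expected step of a 2.3-fold higher number from compound 2 to compound 3 (0.35 log units; beyond the scatter).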

Compound 3, half-maximal inhibitory concentration: 630 nM
Estimate against measurement, compound 3: 1.1-fold (0.05 log units) above; the range from low to high includes it.
By their numbers in this assay, from the lowest: compound 2; then compound 3; then compound 1.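

At this position on the shared core, the change from methyl to methoxy is no longer the only route to a lower number in this assay: there is a 2.1-fold lower number from compound 1 to compound 3 (0.31 log units; beyond the scatter), and also a 2.0-fold higher number from compound 2 to compound 3 (0.31 log units; beyond the scatter). Cyclopropyl has no hydrogen-bond acceptor, so among these compounds a number lower than that of methyl does not depend on having one. Nothing measured here explains this order. As far as these compounds go, whether an amine, an ethoxy group or a longer chain at this position would fall below the number for methoxy remains open.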